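A few compounds are considered here, and "the series" means these few. Any claim that something is new, unique, unknown or untested is made for them only; others in the source may bear on it.

Measured so far in a functional assay on the whole organism with Mus musculus as the target, in the maximal electroshock model, with a stated time of 30 min; a higher number here means that more compound is needed for the effect, a lower number that less compound is needed:
- compound 1 `Cc1cccc(Cl)c1NC(=O)Nc1ccncc1`: 30 mg/kg
- compound 2 `Cc1cccc(Cl)c1NC(=O)Nc1ccccn1`: 100 mg/kg
- compound 3 `O=C(Nc1cccnc1)Nc1c(Cl)cccc1Cl`: > 300 mg/kg (a limit of the assay, not a number)

Compound 3 stands at the top of the numbers shown: in this assay compound 3 gives only > 300 mg/kg, which is a limit and not a measured value, as recorded in the limit of > 300 mg/kg in this assay, at which 1 of the 3 values shown sits. Compound 4 `Cc1cccc(Cl)c1NC(=O)Nc1cccnc1` differs from compound 3 by methyl in place of chloro on an aromatic carbon. For the measured compounds named here, no measured step covers this change. Going by the values given here, the single measured step, a 3.3-fold higher number from compound 1 to compound 2 (0.52 log units; beyond the scatter), concerns the aryl on the other amide-type nitrogen and does not bear directly on the exchange from compound 3 to compound 4; it only shows that compounds 1 and 2, which carry a methyl where compound 3 carries its second chloro, both give numbers rather than a limit. Compound 4 carries the same methyl as compound 1 and compound 2, so the expectation is that compound 4 also returns a number, with a step of an at least 3.0-fold lower number from compound 3 to compound 4 (0.47 log units; beyond the scatter) expected from the limit of compound 3. The estimate for compound 4 in this assay is 100 mg/kg, expected to fall between 30 mg/kg and 300 mg/kg.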

Compound 4, minimum effective dose: 100 mg/kg
For compound 4 middle estimate and measured number coincide at the digits printed; the measured number falls inside the stated range.
By their numbers in this assay, from the lowest: compound 1; then compounds 2 and 4 (each within the scatter of the next). At a limit, above all of these: compound 3.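

In this assay methyl in place of chloro on an aromatic carbon, ortho to a large group, can now be read with the pyridin-3-yl held constant as an at least 3.0-fold lower number from compound 3 to compound 4 (0.47 log units; beyond the scatter) and only the lower bound of that step is known. The starting point of this step is a limit of the assay and not a number, and it belongs to compound 3 alone: the limit of > 300 mg/kg in this assay, at which 1 of the 4 values shown sits. With the methyl kept, pyridin-3-yl in place of pyridin-2-yl gives no change at the digits printed from compound 2 to compound 4 (within the scatter) while pyridin-3-yl in place of pyridin-4-yl gives a 3.3-fold higher number from compound 1 to compound 4 (0.52 log units; beyond the scatter) so among the three methyl compounds pyridin-4-yl alone stands apart, with the lowest number.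

The compounds shown pair methyl and chloro on the pyridin-3-yl compounds only, so it stays open whether the same exchange would carry the same weight with pyridin-2-yl or pyridin-4-yl, and how large the step from compound 3 to compound 4 really is. Also open, on these data alone, is how a fluoro, a methoxy or an ethyl group at this aromatic carbon would compare with the methyl of compound 4.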